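Adding one methoxy to a compound at the assay limit

The compounds below may be only part of what the source reports. "The series", "measured", "known", "first", "only" and "open" are said of these compounds alone.

Compound 1 (`COc1ccc(C(=O)c2sc(Nc3ccc(Cl)cc3)nc2N)cc1`): a limit (> 10000 nM)
Compound 2 (`Nc1nc(Nc2ccc(F)cc2)sc1C(=O)c1ccccc1`): a limit (> 10000 nM)

In a functional assay on HeLa cells (Homo sapiens) for antiproliferative activity, read by cell counting, with a stated time of 2 days (a higher number here means a weaker inhibitor, a lower number a stronger inhibitor), compound 2 reaches only a limit (> 10000 nM), not a number. The same holds across this small set (the limit of > 10000 nM in this assay, at which 2 of the 2 values shown sit), so the data offer no measured potency to start from.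

Compound 3 (`COc1ccc(C(=O)c2sc(Nc3ccc(F)cc3)nc2N)cc1`) comes from compound 2 through one change (methoxy in place of hydrogen on an aromatic carbon): methoxy in place of hydrogen on an aromatic carbon, or phenyl to 4-methoxyphenyl. Among the compounds with values here, no measured pair shows what this change does in this assay. The expectation is therefore no step beyond the scatter, with compound 3 staying weak, because compound 2 sits at a limit (> 10000 nM). The expected step is small (a step that the limit leaves unreadable from compound 2 to compound 3). Compound 3 is estimated at (12000 nM), with an expected range (4000 nM to 30000 nM).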

Compound 3, half-maximal inhibitory concentration: > 10000 nM
Compound 3: a limit, no number; the forecaster's own chance of this, stated with the estimate: 80%; the middle value lies beyond the limit too.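

Compound 3 gives a limit, [ > 10000 nM ], not a number. Compound 1 and compound 2 also sit at limits, so neither step to compound 3 can be read: the limit of > 10000 nM in this assay, at which 3 of the 3 values shown sit. Going by these compounds, whether methoxy in place of hydrogen, or fluoro in place of chloro, changes potency at all stays open.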